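Moving the pyridine nitrogen in an imidazoline ether series

The source may hold more compounds than are shown below. What is called first, only, known or untested is meant among the compounds shown, and "the series" means these compounds.

Compound 1, `CC(Oc1ccccc1-c1ccc(O)cc1)C1=NCCN1`: < 0.3
Compound 2, `CC(Oc1ccccc1-c1cccnc1)C1=NCCN1`: 1
Compound 3, `CC(Sc1ccccc1-c1ccccc1)C1=NCCN1`: < 0.3

Among the compounds with values here, in a functional assay on CHO cells for agonist activity at Alpha-2C adrenergic receptor (Homo sapiens) (on this read-out lower numbers stand for smaller maximal responses and higher numbers for larger maximal responses), compound 2 gives 1, the only plain number among the three. Compound 1 gives < 0.3, which is a limit of the assay. Compound 3 also gives a limit, < 0.3. Compound 2 thus stands apart from the limit of < 0.3 in this assay, at which 2 of the 3 values shown sit. Within the data shown here, the one measured step, a number at least 0.70 higher from compound 1 to compound 2 (beyond the scatter), spans nearly the whole scale of the read-out. Compound 4, `CC(Oc1ccccc1-c1ccccn1)C1=NCCN1`, differs from compound 2 by pyridin-2-yl in place of pyridin-3-yl on an aromatic carbon. Among the measured compounds shown here, no measured step covers this exchange; only a number at least 0.70 higher from compound 1 to compound 2 (beyond the scatter) shows how far a change of the group at this place can move the response. Compound 4 is therefore expected to retain a large part of the response, with an estimated a number 0.30 lower from compound 2 to compound 4 (beyond the scatter). The estimate for compound 4 is 0.7, expected between 0.3 and 1.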

Compound 4, intrinsic activity: the largest response reached, as a fraction of the reference agonist's: < 0.3
Compound 4: no number, only a limit; the forecaster's own chance of this, stated with the estimate: 30%; middle value at least 0.40 from the limit.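

In this assay, putting pyridin-2-yl in place of pyridin-3-yl on the aromatic carbon gives a number at least 0.70 lower from compound 2 to compound 4 (beyond the scatter). The two groups have the same atoms, joined differently, so the response at this place depends on where the nitrogen stands in the ring and not only on what the group contains. Compound 2 alone now stands apart from the others: the limit of < 0.3 in this assay, at which 3 of the 4 values shown sit.

The step from compound 1 to compound 4 cannot be read, as both values are limits. As far as these compounds go, whether pyridin-4-yl, or pyridin-3-yl carrying an added amine, would keep the response stays open.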